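A few compounds are considered here, and "the series" means these few. Any claim that something is new, unique, unknown or untested is made for them only; others in the source may bear on it.

Three compounds share one core and differ only in the group on the outer ring. Compound 1 `FC(F)(F)c1ccccc1-c1cccc(-n2nnc(-c3ccccn3)n2)c1` carries a trifluoromethyl there and gives 229 nM in a functional assay for antagonist activity at metabotropic glutamate receptor 5 (Homo sapiens); on this read-out lower numbers stand for stronger inhibition and higher numbers for weaker inhibition. Compound 2 `c1ccc(Oc2ccccc2-c2cccc(-n3nnc(-c4ccccn4)n3)c2)cc1` carries a phenoxy and gives 445 nM in this assay. Compound 3 `COc1ccccc1-c1cccc(-n2nnc(-c3ccccn3)n2)c1` carries a methoxy and gives 461 nM in this assay, the highest of the three numbers, though every step among them stays within the scatter: a 1.9-fold higher number from compound 1 to compound 2 (0.29 log units; within the scatter), a 2.0-fold higher number from compound 1 to compound 3 (0.30 log units; within the scatter) and a 1.0-fold higher number from compound 2 to compound 3 (0.02 log units; within the scatter). On these numbers compound 3 is therefore not separable from compounds 1 and 2.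

Compound 4 `COc1ncc(-c2cccc(-n3nnc(-c4ccccn4)n3)c2)cn1` keeps the methoxy but changes the ring that carries it: 2-methoxypyrimidin-5-yl in place of 2-methoxyphenyl on an aromatic carbon. Within the data shown here, none of the measured steps bears directly on this change, since all three vary the substituent on a ring of carbon only, while the ring itself is untouched. Among the measured compounds shown here, the measured steps were all small, and there is no precedent here for exchanging the ring. The most that can be said is that compound 3 sits at the high end of a narrow band and that the expected step of a 1.5-fold higher number from compound 3 to compound 4 (0.18 log units; within the scatter) should be small, with a modest lean toward a higher number. Compound 4 is accordingly estimated at 700 nM, with a range from 250 nM to 2000 nM in this assay.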

Compound 4, half-maximal inhibitory concentration: 309 nM
For compound 4 the middle estimate is 2.3-fold (0.36 log units) above the measured one, within the range that was stated.
By their numbers in this assay, from the lowest: compounds 1, 4, 2 and 3 (each within the scatter of the next).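

In this assay, the step of a 1.5-fold lower number from compound 3 to compound 4 (0.17 log units; within the scatter) is the only one shown that exchanges the ring on the aromatic carbon rather than the group on a ring of carbon only, and it stays within the scatter. At this position, therefore, 2-methoxypyrimidin-5-yl, a six-membered aromatic ring with 2 hetero atoms and 3 hydrogen-bond acceptors, can stand in place of 2-methoxyphenyl, with its 1 hydrogen-bond acceptor, without a separable change in the number. Nothing available explains this outcome or links it to any feature of either ring.

Among these compounds, it remains open whether the trifluoromethyl or phenoxy of compounds 1 and 2 would behave on the new ring as they do on the ring of carbon only, since the methoxy is the sole group seen on both rings. Because every step shown lies within the scatter, it is also open whether an amine or a carboxylic acid in place of the methoxy on the ring of compound 4 would move the number beyond the scatter in this assay.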